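The source may hold more compounds than are shown below. What is called first, only, known or untested is meant among the compounds shown, and "the series" means these compounds.

For the measured compounds named here, compound 1, `O=C(NO)c1ccc(NCc2nc(-c3cccc(Cl)c3)nn2-c2ccccc2)cc1`, is one of two compounds measured in an assay on Sf9 cells for inhibition of protein deacetylase HDAC6 (Homo sapiens), read by fluorescence, with a stated time of 40 min, tested at 100 nM (a higher number here means more inhibition at the concentration tested (going by the name of the read-out), a lower number less inhibition), where compound 1 gives 61.2%. The other is compound 2, `COc1ccc(-n2nc(-c3ccc(O)cc3)nc2CNc2ccc(C(=O)NO)cc2)cc1`, which in this assay gives 70.3%. Compound 1 has the lower of the two numbers, but the gap to compound 2 lies within the usual scatter of repeated measurements, so the two values cannot be told apart with confidence. Going by the values given here, no step between compounds that differ in a single place has been measured, so there is no measured change to lean on.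

Compound 3, `Cc1ccsc1-c1nc(CNc2ccc(C(=O)NO)cc2)n(-c2ccccc2)n1`, is not yet measured. It differs from compound 1 in one place: 3-methylthiophen-2-yl in place of 3-chlorophenyl on an aromatic carbon. A six-membered aromatic ring of carbon only gives way to a five-membered aromatic ring with one hetero atom on the same aromatic carbon of the shared core. With nothing in the measured pair to show how this place responds, a step from compound 1 to compound 3 of no more than the scatter is expected, with a slight lean downward, giving an estimated a number 6.2 percentage points lower from compound 1 to compound 3 (within the scatter). Compound 3 is therefore expected to give about 55% in this assay, within 35% to 75%.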

Compound 3, a percentage reported as inhibition, at one concentration (the size of the read-out at that concentration, not a potency): 72.1%
Beside the measured number, compound 3's estimate is 17.1 percentage points below it, and the stated range covers the measured number.
By their numbers in this assay, from the lowest: compounds 1, 2 and 3 (each within the scatter of the next, the first and the last beyond it).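

For the compounds shown here, the step from the 3-chlorophenyl to the 3-methylthiophen-2-yl compound is the first measured change at this place, on an aromatic carbon of a five-membered aromatic ring with 3 nitrogen, between two ring nitrogen atoms. In this assay the number reads (a number 10.9 percentage points higher from compound 1 to compound 3 (beyond the scatter)), a modest step, which shows that this place responds to the group it carries and that a six-membered aromatic ring of carbon only is not needed there, since a five-membered aromatic ring with 1 hetero atom serves at least as well. Nothing available gives a measured reason for this step.

This single step changes the ring, the chlorine and the methyl together, so it cannot say which of these the number follows, or whether the same swap would read alike with the other groups on the shared core left different. Going by these compounds, how a plain thiophen-2-yl, an unsubstituted phenyl, a pyridine ring or a group carrying an amine or a carboxylic acid would read at this place remains open.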